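The source may report more compounds than this note shows. Statements on the series, on what has been measured and on what is new or still open speak of the compounds shown alone.

Compound 1 `CCCCNC(=O)NS(=O)(=O)c1ccc(OCCCO[N+](=O)[O-])cc1`: > 100000 nM (a limit)
Compound 2 `CCCCNC(=O)NS(=O)(=O)c1ccc(OCc2no[n+]([O-])c2-c2ccccc2)cc1`: > 100000 nM (a limit)
Compound 3 `CCCCNC(=O)NS(=O)(=O)c1ccc(OCc2no[n+]([O-])c2C(N)=O)cc1`: 57000 nM

These results come from a functional assay on thoracic aorta (strain Wistar) for inhibition, with Aorta (Rattus norvegicus) as the target, with a stated time of 120 min, in the presence of a further agent that is not named here; on this read-out lower numbers stand for an effect already at smaller amounts and higher numbers for an effect only at larger amounts of compound. For the measured compounds named here, compound 3 holds the only true number here. The other two results sit at a limit: the limit of > 100000 nM in this assay, at which 2 of the 3 values shown sit.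

Compound 4 `CCCCNC(=O)NS(=O)(=O)c1ccc(OCc2no[n+]([O-])c2C#N)cc1` carries cyano in place of carbamoyl on an aromatic carbon. Going by the values given here, two measured steps bear on this. The closer one, an at least 1.7-fold lower number from compound 2 to compound 3 (0.24 log units; that floor lies within the scatter), exchanges a group on the same carbon, while an at least 1.7-fold lower number from compound 1 to compound 3 (0.24 log units; that floor lies within the scatter) exchanges the larger group. Both are only floors, so neither fixes a size, and the expectation is loose.

A moderate move towards a lower number is expected in this assay. The expected step is a 7.1-fold lower number from compound 3 to compound 4 (0.85 log units; beyond the scatter). For compound 4 the estimated value is 8000 nM, within an expected range of 1000 nM to 60000 nM.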

Compound 4, half-maximal effective concentration: 900 nM
Estimate against measurement, compound 4: 8.9-fold (0.95 log units) above, and the stated range ends above it.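

At this ring carbon, cyano in place of carbamoyl gives a 63-fold lower number from compound 3 to compound 4 (1.80 log units; beyond the scatter) in this assay, so exchanging this one small group moves the read-out strongly. Cyano in place of phenyl gives an at least 110-fold lower number from compound 2 to compound 4 (2.04 log units; beyond the scatter), and the cyano-bearing ring group in place of the open chain gives an at least 110-fold lower number from compound 1 to compound 4 (2.04 log units; beyond the scatter). These last two steps are floors and not sizes: the limit of > 100000 nM in this assay, at which 2 of the 4 values shown sit.

From the compounds shown here alone, only phenyl, carbamoyl and cyano stand on this carbon here, so how a carboxylic acid or an amine would compare stays open. Going by these compounds, whether the large step from carbamoyl to cyano would recur on another core is also open.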